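A few compounds are considered here, and "the series" means these few. Any claim that something is new, unique, unknown or untested is made for them only; others in the source may bear on it.

Compound 1 `O=C(Nc1ccc2sc(-c3cccc(F)c3)nc2c1)N1CCCCC1` belongs to a small set of ureas built on a shared core. In an ADME assay on HepG2 cells (Homo sapiens) for inhibition, read by resazurin assay, with a stated time of 48 h (a lower number here means that less compound is needed, a higher number that more compound is needed for the effect), compound 1 gives > 50 uM, which is a limit of the assay and not a number. Compound 2 `O=C(Nc1ccc2sc(-c3ccccc3F)nc2c1)N1CCCC1` gives > 50 uM in this assay, again a limit. Compound 3 `O=C(Nc1ccc2sc(-c3ccc(F)c(F)c3)nc2c1)N1CCC(F)CC1` gives > 50 uM in this assay, also a limit. Compound 1 therefore stands at the limit of > 50 uM in this assay, at which 3 of the 3 values shown sit, and nothing among the numbers shown sets it apart from compound 2 or compound 3.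

Compound 4 `O=C(Nc1ccc2sc(-c3ccccc3)nc2c1)N1CCCCC1` has not yet been measured in this assay. Next to compound 1 it shows (hydrogen in place of fluoro on an aromatic carbon). For the measured compounds named here, no step between two measured compounds is available to guide how large such a change might be in this assay. Given that compound 1 sits at the limit of > 50 uM in this assay, at which 3 of the 3 values shown sit, the step that the limit leaves unreadable from compound 1 to compound 4 is expected to be none beyond the scatter. Compound 4 is thus expected to give about 60 uM in this assay, with a range from 20 uM to 200 uM, and most likely to come back as a limit as well.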

Compound 4, concentration for 90% of the maximal effect: > 50 uM
Compound 4 ended at the assay's limit; the forecaster's own chance of this, stated with the estimate: 85%; the middle value does not contradict the limit.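

No step can be read from compound 1 to compound 4 in this assay since both values are limits of the assay and not numbers: the limit of > 50 uM in this assay, at which 4 of the 4 values shown sit.

The compounds shown leave open whether any urea on the shared core gives an actual number in this assay and how far fluoro and hydrogen differ there.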